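Pyrrole in place of bromohydroxyphenyl on the thiophenone core

The compounds below may be only part of what the source reports. "The series", "measured", "known", "first", "only" and "open" are said of these compounds alone.

Of the compounds shown here, three with a shared core have been measured in a functional assay on MCF7 cells (Homo sapiens) for inhibition, read by MTT assay, with a stated time of 72 h, tested at 10 uM; a higher number here means more inhibition at the concentration tested (going by the name of the read-out), a lower number less inhibition. Compound 1 `CCOC(=O)C1=C(Nc2ccccc2)S/C(=C\c2ccccc2)C1=O` gives 23.6%, compound 2 `CCOC(=O)C1=C(Nc2ccccc2)S/C(=C\c2ccc([N+](=O)[O-])c(O)c2)C1=O` gives 41.5%, and compound 3 `CCOC(=O)C1=C(Nc2ccccc2)S/C(=C\c2ccc(Br)c(O)c2)C1=O` gives 16.4%. Compound 3 thus holds the lowest of the three numbers; its nearest neighbour is compound 1, and the step of a number 7.2 percentage points lower from compound 1 to compound 3 (within the scatter) lies within the scatter, while the step of a number 25.1 percentage points lower from compound 2 to compound 3 (beyond the scatter) is beyond it.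

Compound 4 `CCOC(=O)C1=C(Nc2ccccc2)S/C(=C\c2ccc[nH]2)C1=O` differs from compound 3 in one place: 1H-pyrrol-2-yl in place of 4-bromo-3-hydroxyphenyl on a double-bonded chain carbon bound to a double-bonded ring carbon. For the measured compounds named here, no measured step exchanges the whole aromatic group for a five-membered ring, so the two steps that touch compound 3 bear only indirectly. They show that changes on the group bound to the double-bonded chain carbon can move the read-out modestly in either direction, with the unsubstituted phenyl of compound 1 lying within the scatter of compound 3. Compound 4 is therefore expected to sit near compound 1 or compound 3, with an estimated step of a number 7.6 percentage points higher from compound 3 to compound 4 (within the scatter) that may not exceed the scatter. The estimate for compound 4 in this assay is 24%, with a range from 6% to 48%.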

Compound 4, a percentage reported as inhibition, at one concentration (the size of the read-out at that concentration, not a potency): 18.3%
The estimate for compound 4 lay 5.7 percentage points above the measured number; the range from low to high includes it.
By their numbers in this assay, from the lowest: compounds 3, 4 and 1 (each within the scatter of the next); then compound 2.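

In this assay, exchanging the six-membered aromatic ring for a five-membered one on a double-bonded chain carbon bound to a double-bonded ring carbon gives no separable shift against either neighbour: a number 1.9 percentage points higher from compound 3 to compound 4 (within the scatter), and a number 5.3 percentage points lower from compound 1 to compound 4 (within the scatter). For the compounds shown here, the position therefore accepts 1H-pyrrol-2-yl, a smaller ring carrying a ring nitrogen, in place of both phenyl and 4-bromo-3-hydroxyphenyl, and the only step here that lies beyond the scatter remains the one between the two substituted phenyl groups, a number 25.1 percentage points lower from compound 2 to compound 3 (beyond the scatter). Nothing available offers an explanation for why these compounds fall so close together.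

The compounds shown leave open whether a nitro group on the pyrrole ring would produce a step like the one seen between the substituted phenyl groups, and whether a pyridine ring, a saturated piperidine ring or a phenyl ring bearing a carboxylic acid would be accepted at this position as well. Since each number comes from a single concentration, the compounds also leave open how their potencies compare.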